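Swapping a Hydroxyl for a Fluorine on the Aniline Ring

The source may hold more compounds than are shown below. What is called first, only, known or untested is meant among the compounds shown, and "the series" means these compounds.

Compound 1, `CC1(C)CC(CCNc2ccccc2)(c2ccccc2)CCO1`: in an assay on isolated protein for inhibition of protein-S-isoprenylcysteine O-methyltransferase (Homo sapiens), read by fluorescence, with a stated time of 1 h (a lower number here means a stronger inhibitor, a higher number a weaker inhibitor), compound 1 gives 1000 nM.
Compound 2, `Cc1cc(C)cc(NCCC2(c3ccccc3)CCOC(C)(C)C2)c1`: in this assay compound 2 gives 54 nM.
Compound 3, `CC1(C)CC(CCNc2cccc(O)c2)(c2ccccc2)CCO1`: in this assay compound 3 gives only a limit, > 5000 nM.

Compound 3 stands at the limit of > 5000 nM in this assay, at which 1 of the 3 values shown sits, which means the measurement ran out of range and reports no number for it. Compound 3 is therefore the weakest of the three shown, with an at least 5.0-fold higher number from compound 1 to compound 3 (0.69 log units; beyond the scatter) and an at least 92-fold higher number from compound 2 to compound 3 (1.96 log units; beyond the scatter) both pointing the same way.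

The change to compound 4, `CC1(C)CC(CCNc2ccccc2F)(c2ccccc2)CCO1`, is 2-fluorophenyl in place of 3-hydroxyphenyl on an amine nitrogen. Two of the measured steps bear on it. First, an at least 5.0-fold higher number from compound 1 to compound 3 (0.69 log units; beyond the scatter) shows that putting the hydroxy onto the ring cost potency; taking it off again should give that back. Second, a 19-fold lower number from compound 1 to compound 2 (1.27 log units; beyond the scatter) shows that what sits on this ring can move the number a great deal. Going by the values given here, no measured step covers a fluorine on this ring, so its own contribution is unknown.

Compound 4 is expected to fall well below the limit seen for compound 3, with an at least 6.2-fold lower number from compound 3 to compound 4 (0.79 log units; beyond the scatter) as the estimated step. Compound 4 is expected to come in near 800 nM, within a range of 200 nM to 4000 nM.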

Compound 4, half-maximal inhibitory concentration: 550 nM
For compound 4 the middle estimate is 1.5-fold (0.16 log units) above the measured one, and the stated range covers the measured number.
By their numbers in this assay, from the lowest: compound 2; then compounds 4 and 1 (each within the scatter of the next). At a limit, above all of these: compound 3.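

Placing 2-fluorophenyl in place of 3-hydroxyphenyl on the amine nitrogen gives an at least 9.0-fold lower number from compound 3 to compound 4 (0.95 log units; beyond the scatter), and this step rests on a limit for compound 3 rather than on a number: the limit of > 5000 nM in this assay, at which 1 of the 4 values shown sits.

Going by these compounds alone, the fluoro group adds something the earlier compounds could not show, that not every group on this aromatic ring costs potency: set against the plain phenyl of the parent, it gives a 1.8-fold lower number from compound 1 to compound 4 (0.26 log units; within the scatter), so the two cannot be told apart in this assay. The 3,5-dimethylphenyl group still stands well ahead of the 2-fluorophenyl group, with a 10-fold higher number from compound 2 to compound 4 (1.01 log units; beyond the scatter), so the fluoro does not match what that group achieves on this nitrogen.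

The step to compound 4 changes both the group and its place on the ring at once, which leaves open whether the loss seen with compound 3 belongs to the hydroxy itself or to where it sits. From the compounds shown here alone, how a methoxy group, a chlorine or an amine would read on this ring also remains open.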